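A few compounds are considered here, and "the series" means these few. Any claim that something is new, unique, unknown or untested is made for them only; others in the source may bear on it.

Measured so far in a functional assay on MIA PaCa-2 cells (Homo sapiens) for cytotoxicity, read by MTT assay, with a stated time of 72 h; a lower number here means a stronger inhibitor, a higher number a weaker inhibitor:
Compound 1 `COc1cc(NC2=CC(=O)c3ncncc3C2=O)cc(OC)c1OC` gives 1500 nM.
Compound 2 `COC(=O)c1ccc(NC2=CC(=O)c3ncncc3C2=O)cc1` gives 2200 nM.
Compound 3 `O=C1C(Nc2cccc(B(O)O)c2)=CC(=O)c2ncncc21` reaches only a limit of the assay, > 10000 nM, which is not a number (the limit of > 10000 nM in this assay, at which 1 of the 3 values shown sits).

Compound 2 and compound 1 sit within the usual scatter of each other, so the two numbers cannot be told apart. The unmeasured compound 4 `O=C1C(Nc2ccc(-c3ccccc3)cc2)=CC(=O)c2ncncc21` differs from compound 2 by phenyl in place of methoxycarbonyl on an aromatic carbon. No measured pair shows this change, so its effect is not known from the data shown. The expected step of a 1.2-fold lower number from compound 2 to compound 4 (0.09 log units; within the scatter) is small, no larger than the scatter, in no certain direction. Compound 4 is therefore estimated at 1800 nM, with a range from 500 nM to 7000 nM.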

Compound 4, half-maximal inhibitory concentration: 900 nM
Compound 4: the middle estimate sits 2.0-fold (0.30 log units) above what was measured; the range from low to high includes it.
By their numbers in this assay, from the lowest: compounds 4, 1 and 2 (each within the scatter of the next, the first and the last beyond it). At a limit, above all of these: compound 3.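

In this assay, phenyl in place of methoxycarbonyl on an aromatic carbon, para to a large group, gives a 2.4-fold lower number from compound 2 to compound 4 (0.39 log units; beyond the scatter). This is the only step shown between compounds that differ in one place, and it shows that this position can carry an added aromatic ring, with no hydrogen-bond acceptors, without any loss of strength. Nothing measured here accounts for the step. As far as these compounds go, how an amine, a carboxylic acid or a longer chain would fare at this position stays open, as does whether phenyl would have the same effect at another position on the same ring.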